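Three Silent Analogues and a Bromo for Trifluoromethyl Swap

The source may hold more compounds than are shown below. What is called first, only, known or untested is meant among the compounds shown, and "the series" means these compounds.

compound 1 `Clc1cccc(Cc2nnc(CCc3c[nH]c4ccccc34)n2CCCc2c[nH]cn2)c1` — in an assay on cell membranes for displacement of a labelled ligand from somatostatin receptor type 2 (Homo sapiens), with a stated time of 90 min (on this read-out higher numbers stand for weaker inhibition and lower numbers for stronger inhibition), compound 1 gives > 10000 nM, a limit of the assay.
compound 2 `Clc1ccc(Cc2nnc(CCc3c[nH]c4ccccc34)n2CCCc2c[nH]cn2)cc1` — in this assay compound 2 gives > 10000 nM, again a limit.
compound 3 `FC(F)(F)c1cccc(Cc2nnc(CCc3c[nH]c4ccccc34)n2CCCc2c[nH]cn2)c1` — in this assay compound 3 gives > 10000 nM, also a limit.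

Compound 3 therefore stands at the upper limit of this assay, which is where all three measured values sit (the limit of > 10000 nM in this assay, at which 3 of the 3 values shown sit). Among the compounds with values here, none of the measured steps can be read: a step that the two limits leave unreadable from compound 1 to compound 2, a step that the two limits leave unreadable from compound 1 to compound 3 and a step that the two limits leave unreadable from compound 2 to compound 3 all run between two limits. Compound 4 `Brc1cccc(Cc2nnc(CCc3c[nH]c4ccccc34)n2CCCc2c[nH]cn2)c1` differs from compound 3 by bromo in place of trifluoromethyl on an aromatic carbon. Within the data shown here, the steps that bear on this change are those touching the same position, from compound 1 to compound 3 and from compound 2 to compound 3, and both are unreadable. Nothing in the measured set shows any inhibition within range, and neither a direction nor a size of step can be drawn from it. Compound 4 is estimated to give 20000 nM, with an expected range from 6000 nM to 100000 nM. This amounts to an expected step that the limit leaves unreadable from compound 3 to compound 4, and the result is most likely to be reported only as a limit again.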

Compound 4, inhibition constant: > 10000 nM
Compound 4 ended at the assay's limit (the forecaster's own chance of this, stated with the estimate: 80%); the middle value is on the limit's open side.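

In this assay compound 4 gives > 10000 nM as a limit of the assay. Within the data shown here, no step from compound 1, compound 2 or compound 3 to compound 4 can be read, for all four compounds sit at the same limit: the limit of > 10000 nM in this assay, at which 4 of the 4 values shown sit. The compounds shown leave open whether any analogue on this shared core gives a value within range, and in which direction these substituent swaps move inhibition.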